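Changing the Amide Cap: From Compound 3 to Compound 4

The compounds below may be only part of what the source reports. "The series", "measured", "known", "first", "only" and "open" are said of these compounds alone.

Compound 1 `CN1[C@@H]2c3[nH]c4ccccc4c3C[C@H]1[C@H](C#N)N1[C@@H](CNC(=O)c3ccc(Cl)cc3)c3[nH]c4ccccc4c3C[C@@H]21`: 110 nM
Compound 2 `CN1[C@@H]2c3[nH]c4ccccc4c3C[C@H]1[C@H](C#N)N1[C@@H](CNC(=O)c3ccc(F)cc3)c3[nH]c4ccccc4c3C[C@@H]21`: 310 nM
Compound 3 `CN1[C@@H]2c3[nH]c4ccccc4c3C[C@H]1[C@H](C#N)N1[C@@H](CNC(=O)c3cc4ccccc4s3)c3[nH]c4ccccc4c3C[C@@H]21`: 240 nM

In a functional assay on BGC-823 cells (Homo sapiens) for cytotoxicity, read by MTT assay, with a stated time of 72 h (on this read-out lower numbers stand for stronger inhibition and higher numbers for weaker inhibition), compound 3 gives 240 nM, the second highest of the three numbers: within the scatter of compound 2, but beyond it against compound 1. Compound 4 `COc1ccc(/C=C/C(=O)NC[C@H]2c3[nH]c4ccccc4c3C[C@H]3[C@H]4c5[nH]c6ccccc6c5C[C@@H]([C@H](C#N)N23)N4C)cc1` differs from compound 3 by 2-(4-methoxyphenyl)ethenyl in place of 1-benzothiophen-2-yl on a carbonyl carbon. The changes already seen at that carbonyl carbon were small: a 2.2-fold higher number from compound 1 to compound 3 (0.34 log units; beyond the scatter) and a 1.3-fold lower number from compound 2 to compound 3 (0.11 log units; within the scatter). A similar swap of the group on the carbonyl carbon is therefore expected to move the number only a little, in either direction. Compound 4 is expected to show a 1.3-fold higher number from compound 3 to compound 4 (0.10 log units; within the scatter). The estimate for compound 4 is 300 nM, with a range from 120 nM to 750 nM.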

Compound 4, half-maximal inhibitory concentration: 5450 nM
Compound 4: middle estimate off by 18-fold (1.26 log units), on the low side, and the stated range ends below it.
By their numbers in this assay, from the lowest: compound 1; then compounds 3 and 2 (each within the scatter of the next); then compound 4.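

In this assay, the group on this carbonyl carbon matters far more than the earlier swaps suggested: 2-(4-methoxyphenyl)ethenyl gives a 23-fold higher number from compound 3 to compound 4 (1.36 log units; beyond the scatter), an 18-fold higher number from compound 2 to compound 4 (1.25 log units; beyond the scatter) and a 50-fold higher number from compound 1 to compound 4 (1.70 log units; beyond the scatter). The three tolerated groups are all aromatic rings on the carbonyl carbon, whereas the entering group brings a double bond outside aromatic rings. Nothing available here explains this loss. On these data alone, whether the double bond or the methoxy group carries the loss stays open. A plain 2-phenylethenyl group and a saturated 2-(4-methoxyphenyl)ethyl chain would separate the two.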